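A few compounds are considered here, and "the series" means these few. Any claim that something is new, unique, unknown or untested is made for them only; others in the source may bear on it.

Notes on the series. Compound 1 `c1ccc2c(C3CCNC3)cccc2c1` carries the unsubstituted amine in the five-membered ring. In an assay on CHO-K1 cells for binding affinity to D(3) dopamine receptor (Rattus norvegicus) (on this read-out higher numbers stand for weaker inhibition and lower numbers for stronger inhibition), compound 1 gives > 1000 nM, which is a limit of the assay and not a number. Compound 2 `CN1CCC(C2=CN=CCC2)C1` is the second measured member. In this assay compound 2 gives > 1000 nM, also a limit of the assay and not a number. Compound 1 thus stands at the limit of > 1000 nM in this assay, at which 2 of the 2 values shown sit. For the measured compounds named here, neither measured compound supplies a number, so no step between measured compounds can be drawn, and the two limits show only that both lie at the same edge of this assay.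

Compound 3 `CCCN1CCC(c2cccc3ccccc23)C1` has not been measured. It differs from compound 1 by propyl in place of hydrogen on an amine nitrogen in a ring. Nothing measured in this assay tells how that change acts. Compound 3 is therefore expected in this assay at roughly 1500 nM, within 300 nM to 8000 nM, with a real chance that again only a limit is returned. The expected step from compound 1 to compound 3 of a step that the limit leaves unreadable from compound 1 to compound 3 starts from a limit and is not expected to be a change beyond the scatter in either direction.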

Compound 3, half-maximal inhibitory concentration: > 1000 nM
Compound 3: only a limit was reported (the forecaster's own chance of this, stated with the estimate: 55%); the middle value is on the limit's open side.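

In this assay compound 3 gives > 1000 nM, a limit of the assay and not a number. For the compounds shown here, compound 1 also stands at a limit, so no step from compound 1 to compound 3 can be read. The compounds shown leave open how propyl in place of hydrogen on an amine nitrogen in a ring acts in this assay, and how far each compound lies past that edge: the limit of > 1000 nM in this assay, at which 3 of the 3 values shown sit.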